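Isopropyl in place of cyano on compound 1

The source may hold more compounds than are shown below. What is called first, only, known or untested is meant among the compounds shown, and "the series" means these compounds.

In an ADME assay on microsomes from liver (Homo sapiens) for metabolic stability, read by LC-MS, using NADPH, tested at 1 uM (a higher number here means that the compound lasts longer, a lower number that the compound disappears faster), compound 1 `N#Cc1cnc(NC(=O)CCCOc2ccccc2)s1` gives 0.15 h as its reading, and compound 2 `Cc1cnc(NC(=O)CCCOc2cccc(Cl)n2)s1` gives 0.117 h as its reading. The two stand within the scatter of each other, so compound 1 cannot be separated from compound 2 on these numbers.

Compound 3 `CC(C)c1cnc(NC(=O)CCCOc2ccccc2)s1` keeps the core of compound 1 and carries isopropyl in place of cyano on an aromatic carbon, next to the ring sulfur (isopropyl in place of cyano on an aromatic carbon). Within the data shown here, no two measured compounds differ in one place only, so the data hold no measured step for this change. In this assay a small fall is expected, estimated as a 1.5-fold lower number from compound 1 to compound 3 (0.18 log units; within the scatter) and so within the scatter. Compound 3 is estimated at 0.1 h (range 0.04 h to 0.25 h).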

Compound 3, half-life: 0.117 h
Compound 3: middle estimate off by 1.2-fold (0.07 log units), on the low side, within the range that was stated.
By their numbers in this assay, from the lowest: compounds 2, 3 and 1 (each within the scatter of the next).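

Exchanging cyano for isopropyl on this aromatic carbon, next to the ring sulfur, gives a 1.3-fold lower number from compound 1 to compound 3 (0.11 log units; within the scatter) in this assay. Among these compounds, this is the first comparison that isolates this position, as compound 1 and compound 2 differ in more than one place, and on this reading the half-life does not separate the two groups. Nothing in the available data explains the result.

On these data alone, whether another group at this position, such as an amine, a carboxylic acid or a trifluoromethyl group, would give a reading clear of the scatter remains open. As far as these compounds go, it is also open whether cyano and isopropyl would read alike in a compound that carries the chlorine of compound 2.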